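Nitro in Place of Ethoxycarbonyl on the Shared Core

A few compounds are considered here, and "the series" means these few. Any claim that something is new, unique, unknown or untested is made for them only; others in the source may bear on it.

Compound 1 `N#CC1CN1C(=O)Nc1ccc(F)cc1` gives 5000 nM in a functional assay on RPMI-8226 cells (Homo sapiens) for inhibition; on this read-out lower numbers stand for stronger inhibition and higher numbers for weaker inhibition. Compound 2 `CCOC(=O)c1ccc(NC(=O)N2CC2C#N)cc1` gives 3000 nM in this assay; the step of a 1.7-fold lower number from compound 1 to compound 2 (0.22 log units; within the scatter) is the only one measured, so compound 2 and compound 1 lie within the scatter of each other and neither stands apart. Compound 3 `N#CC1CN1C(=O)Nc1ccc([N+](=O)[O-])cc1` differs from compound 2 by nitro in place of ethoxycarbonyl on an aromatic carbon. Because the earlier exchange on that same carbon, a 1.7-fold lower number from compound 1 to compound 2 (0.22 log units; within the scatter), stayed within the scatter, the step of no change at the digits printed from compound 2 to compound 3 (within the scatter) is expected to stay within it too. Compound 3 is estimated at 3000 nM, between 1000 nM and 9000 nM.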

Compound 3, half-maximal inhibitory concentration: 9100 nM
For compound 3 the middle estimate is 3.0-fold (0.48 log units) below the measured one, and the stated range ends below it.
By their numbers in this assay, from the lowest: compounds 2, 1 and 3 (each within the scatter of the next, the first and the last beyond it).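

On this aromatic carbon, a change of group can move the number beyond the scatter: in this assay, nitro in place of ethoxycarbonyl gives (a 3.0-fold higher number from compound 2 to compound 3 (0.48 log units; beyond the scatter)). Nitro in place of fluoro stays within the scatter (a 1.8-fold higher number from compound 1 to compound 3 (0.26 log units; within the scatter)), so only the ethoxycarbonyl and nitro pair stands apart, and only modestly. No measurement shown gives a reason for this gap. From the compounds shown here alone, it remains open whether an amine, a carboxylic acid or a longer ester chain on this carbon would give a number outside those seen so far.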